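Cytotoxicity notes on a small amide series

A few compounds are considered here, and "the series" means these few. Any claim that something is new, unique, unknown or untested is made for them only; others in the source may bear on it.

Going by the values given here, compound 3 `O=C(CCSc1nnc(-c2ccncc2)s1)NCc1ccccc1` is the only member with a number in an ADME assay on BHK-21 cells (Mesocricetus auratus) for cytotoxicity, with a stated time of 3 days; on this read-out higher numbers stand for lower toxicity in this test and lower numbers for higher toxicity in this test; compound 3 gives 18700 nM. Compound 1 `CC(Sc1nnc(-c2ccncc2)s1)C(=O)Nc1ccccc1` reaches only a limit of this assay, > 50000 nM. Compound 2 `CC(Sc1nnc(-c2ccncc2)s1)C(=O)NCc1ccccc1` likewise stops at a limit, > 50000 nM. Among the compounds with values here, the one step between measured neighbours, a step that the two limits leave unreadable from compound 1 to compound 2, is left unreadable by the two limits, so the series offers no readable step at all; what it does show is the limit of > 50000 nM in this assay, at which 2 of the 3 values shown sit.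

Compound 4 `O=C(CCSc1nnc(-c2ccncc2)s1)Nc1ccccc1Cl` differs from compound 3 as 2-chlorophenyl in place of benzyl on an amide-type nitrogen. Within the data shown here, no measured step bears directly on this change: compound 1 and compound 3 differ both at the amide-type nitrogen and in the chain, so their pair cannot be read as a single step. With nothing pointing beyond the scatter, compound 4 is expected to sit near compound 3, if anything drifting toward the limit where compound 1 and compound 2 sit, a step estimated at a 1.5-fold higher number from compound 3 to compound 4 (0.18 log units; within the scatter). The estimate for compound 4 is 28000 nM, with a range from 11000 nM to 60000 nM.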

Compound 4, half-maximal cytotoxic concentration: > 50000 nM
Compound 4: only a limit was reported (the forecaster's own chance of this, stated with the estimate: 35%); at least 1.7-fold (0.25 log units) between middle value and limit.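

In this assay, the group on the amide-type nitrogen alone moves the read-out with the rest of the structure held constant, and 2-chlorophenyl in place of benzyl gives an at least 2.6-fold higher number from compound 3 to compound 4 (0.42 log units; beyond the scatter). Compound 4 gives > 50000 nM, which is a limit of the assay and not a number, so this step has a minimum size only. Compound 3 remains the only member with a number, and the series gathers further at a single point: the limit of > 50000 nM in this assay, at which 3 of the 4 values shown sit.

The change removes benzyl and brings in both a directly attached ring and a chlorine, and the compounds shown do not separate these two features. Going by these compounds, a 2-chlorobenzyl group on the same nitrogen would bear on that question, while the true size of the step stays open.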